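Nitro to Fluoro Swap on a Fused Sulfonamide Core

A few compounds are considered here, and "the series" means these few. Any claim that something is new, unique, unknown or untested is made for them only; others in the source may bear on it.

Measured compounds:
compound 1 `O=S(=O)(c1ccc(-c2cnc(C3CC3)o2)cc1)N1CCCOc2cc(F)ccc21` — 30 nM
compound 2 `O=[N+]([O-])c1ccc2c(c1)OCCCN2S(=O)(=O)c1ccc(-c2cnc(C3CC3)o2)cc1` — 145 nM
compound 3 `O=[N+]([O-])c1ccc2c(c1)N(S(=O)(=O)c1ccc(-c3cnc(C4CC4)o3)cc1)CCCO2` — 133 nM

In a functional assay on HCT-116 cells (Homo sapiens) for antiproliferative activity, read by MTT assay, with a stated time of 72 h (a lower number here means a stronger inhibitor, a higher number a weaker inhibitor), compound 1 gives 30 nM, compound 2 gives 145 nM and compound 3 gives 133 nM. The difference between the cores of compound 2 and compound 3 is not broken down here; their values lie within the scatter of each other. One change is seen twice. From compound 2 to compound 1 it is fluoro in place of nitro on an aromatic carbon, and it made a 4.8-fold lower number from compound 2 to compound 1 (0.68 log units; beyond the scatter). From compound 3 to compound 4 `O=S(=O)(c1ccc(-c2cnc(C3CC3)o2)cc1)N1CCCOc2ccc(F)cc21` it is fluoro in place of nitro on an aromatic carbon, the same change at the same place. In this assay compound 4 is expected to show a step of about a 4.4-fold lower number from compound 3 to compound 4 (0.65 log units; beyond the scatter), resting on the step seen from compound 2 to compound 1, a 4.8-fold lower number from compound 2 to compound 1 (0.68 log units; beyond the scatter). Compound 4 is therefore estimated at 30 nM, between 12 nM and 80 nM.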

Compound 4, half-maximal inhibitory concentration: 24 nM
Estimate against measurement, compound 4: 1.3-fold (0.10 log units) above; the range from low to high includes it.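

In this assay, fluoro in place of nitro on an aromatic carbon gave a 5.5-fold lower number from compound 3 to compound 4 (0.74 log units; beyond the scatter), and this step sits close to the one seen earlier on the other core: the same change on two cores in this assay, a 4.8-fold lower number (0.68 log units; beyond the scatter) from compound 2 to compound 1 and a 5.5-fold lower number (0.74 log units; beyond the scatter) from compound 3 to compound 4, 1.1-fold (0.06 log units) apart, within the scatter of two such steps. Within this series, then, the change carried from one core to the other with its size kept, although this rests on only two pairs of compounds in a single cell assay. It does not show that the step would hold on any other core or in any other assay, and it does not explain why the fluoro compounds give the lower numbers.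

The compounds shown leave open what an amine, a nitrile or a carboxylic acid would give on that aromatic carbon in place of fluoro or nitro.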